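The compounds below may be only part of what the source reports. "The series", "measured", "known", "first", "only" and "open" are said of these compounds alone.

Measured compounds in a functional assay on Huh-7 cells (Homo sapiens) for inhibition, read by sulforhodamine B assay, with a stated time of 72 h; a higher number here means a weaker inhibitor, a lower number a stronger inhibitor:

Compound 1, `COc1ccc2cc(C(C)c3nnc4n3N=C(c3ccc([N+](=O)[O-])cc3)CS4)ccc2c1`, gives 14700 nM in this assay.
Compound 2, `COc1ccc2cc(C(C)c3nnc4n3N=C(c3ccc(Br)cc3)CS4)ccc2c1`, gives 9300 nM in this assay.
Compound 3, `CC(C)Cc1ccc(C(C)c2nnc3n2N=C(c2ccc(Br)cc2)CS3)cc1`, gives 4900 nM in this assay.

Compound 1 and compound 2 share a core and differ in one place: nitro in place of bromo on an aromatic carbon. That change made the step of a 1.6-fold higher number from compound 2 to compound 1 (0.20 log units; within the scatter), so the two numbers cannot be told apart with confidence. Compound 3 carries a different core; the difference between the core of compound 2 and the core of compound 3 is not broken down here. The values of compound 3 and compound 2 lie within the scatter of each other, while compound 1 stands beyond the scatter relative to compound 3.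

Compound 4, `CC(C)Cc1ccc(C(C)c2nnc3n2N=C(c2ccc([N+](=O)[O-])cc2)CS3)cc1`, has not yet been measured. It differs from compound 3 by nitro in place of bromo on an aromatic carbon. The place of this change reads word for word as the place of the change from compound 2 to compound 1, so it is the same change, here made on the core of compound 3 rather than on that of compound 2. Since the earlier step was a 1.6-fold higher number from compound 2 to compound 1 (0.20 log units; within the scatter), the step from compound 3 to compound 4 is expected to be of similar size, a 1.6-fold higher number from compound 3 to compound 4 (0.20 log units; within the scatter), resting on that single earlier pair. On this basis compound 4 is estimated at 7800 nM in this assay, with a likely range from 4000 nM to 16000 nM.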

Compound 4, half-maximal inhibitory concentration: "not active" (no number reported)
Compound 4: no number reported, and the estimate cannot be compared.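

Among these compounds, compound 4 was reported as "not active" in this assay, with no number given, so no step from compound 3 to compound 4 can be read. No measured evidence bears on this result. The compounds shown leave open whether the change from 4-bromophenyl to 4-nitrophenyl acts alike on the core of compound 3 and on that of compound 2.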